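Removing the carboxy from compound 1: an expected step

The source may hold more compounds than are shown below. What is called first, only, known or untested is meant among the compounds shown, and "the series" means these compounds.

Compound 1 `COc1ccc(NC(=O)C(=O)c2cn(C(C)(C)COCC(=O)O)c3ccccc23)cn1` was tested in a functional assay on FaDu cells (Homo sapiens) for cytotoxicity, read by MTT assay, with a stated time of 72 h; on this read-out lower numbers stand for higher toxicity in this test and higher numbers for lower toxicity in this test. In this assay compound 1 gives > 10000 nM, which is a limit of the assay rather than a number. Compound 1 thus stands at the limit of > 10000 nM in this assay, at which 1 of the 2 values shown sits, so its place on the scale is known only as a boundary. A second compound on the shared core, compound 2 `COCCn1cc(C(=O)C(=O)Nc2ccc(OC(C)(C)C)nc2)c2ccccc21`, was also measured. In this assay compound 2 gives 858 nM. Going by the values given here, compounds 1 and 2 differ in more than one place, so their two values show only that compound 2 sits at a number while compound 1 sits at a limit.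

The account follows the step from compound 1 to compound 3 `COCC(C)(C)n1cc(C(=O)C(=O)Nc2ccc(OC)nc2)c2ccccc21`, which has not yet been measured in this assay. The change is hydrogen in place of carboxy on a saturated chain carbon bound to an oxygen on a saturated carbon. Cut one bond further out, it reads carboxymethoxy to methoxy. Among the compounds with values here, no measured pair carries this change, so its size cannot be read from the data. He expects the step to go toward lower numbers because compound 2 gives 858 nM, a number rather than a limit, and compound 3 is nearer in build to compound 2 than compound 1 is. The expected step is an at least 6.6-fold lower number from compound 1 to compound 3 (0.82 log units; beyond the scatter). Compound 3 is estimated at 1500 nM, with a range from 300 nM to 8000 nM.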

Compound 3, concentration lethal to 50% of the cells in the FaDu assay: 137 nM
Beside the measured number, compound 3's estimate is 11-fold (1.04 log units) above it, and the stated range ends above it.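

Going by these compounds alone, in the FaDu assay the change from carboxy to hydrogen on a saturated chain carbon bound to an oxygen on a saturated carbon now has a size, read as an at least 72-fold lower number from compound 1 to compound 3 (1.86 log units; beyond the scatter), and it is the first reading for a change in one place alone on the shared core. That size remains a bound and not an exact gap, since compound 1 sits at a limit in this test, not at a number: the limit of > 10000 nM in the FaDu assay, at which 1 of the 3 values shown sits. In a physicochemical assay for solubility, in phosphate buffer, at pH 7.4 (a lower number here means a less soluble compound, a higher number a more soluble compound), the step for the same change cannot be read, since compound 1 sits at a limit there too: the limit of <= 200000 nM in the physicochemical assay, at which 1 of the 2 values shown sits. In the physicochemical assay compound 1 gives <= 200000 nM, which is a limit and not a number. In the physicochemical assay compound 3 gives 10000 nM.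

The compounds shown leave open whether this large step belongs to carboxy in particular or whether another group at this place, such as an amine or an amide, would give a number nearer to that of compound 3 or to the limit of compound 1. They also leave open how far the step in the FaDu assay reaches beyond its bound, and how the same change would read on a core with other substituents.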